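The source may hold more compounds than are shown below. What is called first, only, known or untested is meant among the compounds shown, and "the series" means these compounds.

In an ADME assay on MDBK cells (Bos taurus) for cytotoxicity, read by MTT assay, with a stated time of 96 h (a higher number here means that more compound is tolerated, a lower number that less compound is tolerated), three compounds built on one shared core have been measured. Compound 1 `Cn1c(-c2ccc(NC(=O)CN3CCCC3)cc2)nc2cc(C(F)(F)F)ccc21` gives 65000 nM. Compound 2 `CC(=O)Nc1ccc(-c2nc3cc(C(F)(F)F)ccc3n2C)cc1` gives 46000 nM, and compound 3 `Cn1c(-c2ccc(N)cc2)nc2cc(C(F)(F)F)ccc21` gives 74000 nM. These numbers sit close together: the steps are a 1.4-fold lower number from compound 1 to compound 2 (0.15 log units; within the scatter), a 1.1-fold higher number from compound 1 to compound 3 (0.06 log units; within the scatter) and a 1.6-fold higher number from compound 2 to compound 3 (0.21 log units; within the scatter), so compound 2 is not set apart from compound 1 or compound 3 by more than the usual scatter.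

Compound 4 `CC(=O)Nc1ccc(-c2nc3cc(C(F)(F)F)ccc3[nH]2)cc1` has not yet been measured. Set against compound 2, the change is hydrogen in place of methyl on an aromatic nitrogen. None of the three measured steps touches this aromatic nitrogen; each of them alters the group on the nitrogen attached to the aromatic ring, and each stays within the scatter. There is thus no measured guide for the methyl on the ring nitrogen, and no step beyond the scatter is expected for it.

Compound 4 is therefore expected to give about 46000 nM in this assay, with a range from 23000 nM to 92000 nM. The expected step is no change at the digits printed from compound 2 to compound 4 (within the scatter), which is intended to lie within the scatter.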

Compound 4, half-maximal cytotoxic concentration: 50000 nM
Beside the measured number, compound 4's estimate is 1.1-fold (0.04 log units) below it; measured number inside the range.
By their numbers in this assay, from the lowest: compounds 2, 4, 1 and 3 (each within the scatter of the next).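

Within the data shown here, all three earlier steps changed the group on the nitrogen attached to the aromatic ring, so this is the first measured change on the aromatic nitrogen of the five-membered ring. In this assay, hydrogen in place of methyl at this position gives a 1.1-fold higher number from compound 2 to compound 4 (0.04 log units; within the scatter), so with the acetyl group in place, this change does not set the two compounds apart. No measurement is available that would explain this result.

The compounds shown leave open whether a longer chain such as ethyl, or a benzyl group, on this aromatic nitrogen would also stay within the scatter of compound 2. They also leave open whether the same change would stay within the scatter with the free amine of compound 3 or the ((pyrrolidin-1-yl)methyl)carbonyl group of compound 1 on the nitrogen attached to the aromatic ring.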